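Fluoro to chloro on the 2-fluorophenyl group

The source may hold more compounds than are shown below. What is called first, only, known or untested is meant among the compounds shown, and "the series" means these compounds.

Measured in a functional assay on MCF7 cells (Homo sapiens) for inhibition, read by MTT assay, with a stated time of 48 h, tested at 10 uM; on this read-out higher numbers stand for more inhibition of growth at the one concentration tested and lower numbers for less inhibition of growth:
- compound 1 `CN1CC[C@H](c2c(O)cc(O)c3c(=O)cc(/C=C/c4ccc(Cl)cc4)oc23)[C@H](O)C1`: 10%
- compound 2 `CN1CC[C@H](c2c(O)cc(O)c3c(=O)cc(/C=C/c4ccccc4F)oc23)[C@H](O)C1`: 62%

Compound 2 stands highest of the two measured compounds in this assay, at 62%. The next case is compound 3 `CN1CC[C@H](c2c(O)cc(O)c3c(=O)cc(/C=C/c4ccccc4Cl)oc23)[C@H](O)C1`, with this change from compound 2: chloro in place of fluoro on an aromatic carbon. That is chloro in place of fluoro on an aromatic carbon, ortho to a large group. For the measured compounds named here, only one measured step bears on it: a number 52 percentage points higher from compound 1 to compound 2 (beyond the scatter). From the compounds shown here alone, that step is large, but the halogen and its place change together, so the share of the halogen alone remains unknown. Compound 3 keeps the halogen place of compound 2 and carries the halogen of compound 1. The expected change is a moderate fall, much smaller than that large step: a number 12 percentage points lower from compound 2 to compound 3 (beyond the scatter). Compound 3 is estimated at 50%, with an expected range of 25% to 72%.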

Compound 3, percent growth inhibition at one concentration: 63%
Compound 3: the middle estimate sits 13 percentage points below what was measured; measured number inside the range.
By their numbers in this assay, from the lowest: compound 1; then compounds 2 and 3 (each within the scatter of the next).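

In this assay, chloro in place of fluoro on an aromatic carbon, ortho to a large group, gives a number 1 percentage points higher from compound 2 to compound 3 (within the scatter), so the two halogens cannot be told apart at this place. With chloro held constant, 2-chlorophenyl in place of 4-chlorophenyl gives a number 53 percentage points higher from compound 1 to compound 3 (beyond the scatter): this separates the place of the halogen from its identity, and a change of place alone matches the size of the large step seen earlier. No evidence on hand bears on the reason for this dependence on place.

From the compounds shown here alone, it remains open whether a halogen is needed on this aromatic carbon, or whether a methoxy group or an amine in place of chloro would hold the number of compound 3. The result also leaves open how these compounds compare at other concentrations.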